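This account rests on a few compounds, and the source may have more. Where it says the series, first, only, none or still open, it means among the compounds named here.

Compound 2 `CCCCC#Cc1nc(N)c2ncn([C@H]3[C@H](O)[C@H](O)[C@@H]4C[C@@H]43)c2n1` gives 65 nM in an assay on RBL-2H3 cells for displacement of a labelled ligand from adenosine receptor A3 (Rattus norvegicus), with a stated time of 60 min (on this read-out higher numbers stand for weaker inhibition and lower numbers for stronger inhibition), the highest of the two numbers seen so far. Compound 1 `CCCCC#Cc1nc(NC2CC2)c2ncn([C@H]3[C@H](O)[C@H](O)[C@@H]4C[C@@H]43)c2n1` gives 39 nM in this assay. Going by the values given here, the only measured step at this nitrogen is a 1.7-fold higher number from compound 1 to compound 2 (0.22 log units; within the scatter). Compound 3 `CCCCC#Cc1nc(NCc2cccc(Br)c2)c2ncn([C@H]3[C@H](O)[C@H](O)[C@@H]4C[C@@H]43)c2n1` differs from compound 2 in that (3-bromobenzyl in place of hydrogen on a nitrogen on an aromatic ring). Among the compounds with values here, the one step at this position did not move beyond the scatter, so the expectation for compound 3 is only a modest shift towards lower numbers, a 2.2-fold lower number from compound 2 to compound 3 (0.34 log units; beyond the scatter). Compound 3 is therefore estimated at 30 nM in this assay, within 8 nM to 100 nM.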

Compound 3, inhibition constant: 59 nM
Compound 3: middle estimate off by 2.0-fold (0.29 log units), on the low side; low and high end bracket the measured number.
By their numbers in this assay, from the lowest: compounds 1, 3 and 2 (each within the scatter of the next).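

In this assay, 3-bromobenzyl on this nitrogen gives a 1.1-fold lower number from compound 2 to compound 3 (0.04 log units; within the scatter), and the change from cyclopropyl gives a 1.5-fold higher number from compound 1 to compound 3 (0.18 log units; within the scatter). Across the three compounds shown, hydrogen, cyclopropyl and 3-bromobenzyl therefore all stay within the scatter of one another, so even a group of 8 heavy atoms with an aromatic ring leaves the number in the same range. Nothing available accounts for this flat result. From the compounds shown here alone, it remains open whether a plain benzyl, a longer alkyl chain or a carboxylic acid on this nitrogen would stay in that range.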